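The source may report more compounds than this note shows. Statements on the series, on what has been measured and on what is new or still open speak of the compounds shown alone.

Three measured compounds and one unmeasured compound share a single core. Compound 1 `OCC(O)COc1nc(N2CCCCC2)c2nc(OCC(O)CO)nc(N3CCCCC3)c2n1`, compound 2 `OCC(O)COc1nc(N2CCCCC2)c2nc(OC[C@@H](O)CO)nc(N3CCCCC3)c2n1` and compound 3 `COc1nc(N2CCCCC2)c2nc(OC)nc(N3CCCCC3)c2n1` have been tested; compound 4 `OCC(O)COc1nc(N2CCCCC2)c2nc(OC[C@H](O)CO)nc(N3CCCCC3)c2n1` has not. In a functional assay on L1210 cells (Mus musculus) for inhibition, read by thymidine incorporation, tested at 10 uM (a lower number here means a weaker effect, a higher number a stronger effect of the compound at the concentration tested), compound 1 gives 32%. In this assay compound 2 gives 37%, and compound 3 gives 39%. Compound 2 thus stands second highest of the three numbers, with compound 3 nearest and compound 1 furthest, and both of those gaps lie within the scatter, so the three compounds cannot be separated on these data.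

The step to compound 4 changes nothing in the atoms or bonds: the two compounds have the same atoms and bonds; at least one stereo element is drawn with a configuration in one of them and without one in the other: 1 of 2 stereo elements differ; a stereocentre at a saturated chain carbon is drawn S in compound 2 and R in compound 4. Among the compounds with values here, the only measured step that bears on it is the one from compound 1 to compound 2, where the fact that one of compounds 1 and 2 is drawn with a defined configuration and the other without, at the place where they differ is the sole difference, and that step came to a number 5 percentage points higher from compound 1 to compound 2 (within the scatter). With a drawn configuration against an undrawn one making no difference beyond the scatter, the exchange of one drawn configuration for the other is expected to make none either. The step from compound 2 to compound 4 is therefore expected to be a number 2 percentage points lower from compound 2 to compound 4 (within the scatter). Compound 4 is estimated to give 35% in this assay, expected to lie between 22% and 48%.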

Compound 4, a percentage reported as inhibition, at one concentration (the size of the read-out at that concentration, not a potency): 32%
Estimate against measurement, compound 4: 3 percentage points above, and the stated range covers the measured number.
By their numbers in this assay, from the lowest: compounds 1, 4, 2 and 3 (each within the scatter of the next).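

Within the data shown here, with compound 4 measured, both drawn configurations at this saturated chain carbon can be compared directly in this assay, which the earlier compounds did not allow: exchanging S for R gives a number 5 percentage points lower from compound 2 to compound 4 (within the scatter). The step from the form drawn without a configuration at this carbon to the R form gives no change at the digits printed from compound 1 to compound 4 (within the scatter), so the R form now has its own comparison with the undrawn form, alongside the earlier one for the S form. On these data, neither drawn configuration can be separated from the other or from the undrawn form, and no preference at this stereocentre can be read at the concentration tested.

The stereocentre on the second chain is drawn without a configuration in all of these compounds, so it remains open whether defining both centres would give a step beyond the scatter. From the compounds shown here alone, it is also open whether an amine, a carboxylic acid or a longer chain in place of these chains would move the number in this assay beyond the scatter.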